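Cytotoxicity Notes: Compound 3 to Compound 4

The source may report more compounds than this note shows. Statements on the series, on what has been measured and on what is new or still open speak of the compounds shown alone.

Compound 1 `CCCCC(CC)CNc1ncc(C(Oc2ccc3cc(Br)ccc3c2)c2ccc(Cl)cc2)s1` and compound 2 `COCCNc1ncc(C(Oc2ccc3cc(Br)ccc3c2)c2ccc(Cl)cc2)s1` share the core with compound 3 `COc1ccc(C(=O)Nc2ncc(C(Oc3ccc4cc(Br)ccc4c3)c3ccc(Cl)cc3)s2)cc1`. In an ADME assay on HepG2 2.2.15 cells (Homo sapiens) for cytotoxicity (a higher number here means that more compound is tolerated, a lower number that less compound is tolerated), compound 1 is reported as "not toxic" (no number reported). Compound 2 likewise is reported as "not toxic" (no number reported). In this assay compound 3 gives > 50000 nM, which is a limit of the assay and not a number. Compound 3 thus sits at the limit of > 50000 nM in this assay, at which 1 of the 3 values shown sits. Compound 4 `O=C(Nc1ncc(C(Oc2ccc3cc(Br)ccc3c2)c2ccc(Cl)cc2)s1)c1ccc(Cl)nc1` differs from compound 3 by 6-chloropyridin-3-yl in place of 4-methoxyphenyl on a carbonyl carbon. No measured step in this series connects two compounds that differ in one place, so the size of the change cannot be read from the data shown; the step of a number no higher from compound 3 to compound 4 (the limit leaves the size open) is expected to be none beyond the scatter. Compound 4 is therefore estimated at 50000 nM, with a range from 15000 nM to 100000 nM, and a limit rather than a number is likely.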

Compound 4, half-maximal cytotoxic concentration: "not toxic" (no number reported)
Compound 4: no number reported, and the estimate cannot be compared.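

Among the compounds shown here, no step from compound 3 to compound 4 can be read in this assay, as neither carries a single number. Compound 3 holds only a limit: the limit of > 50000 nM in this assay, at which 1 of the 4 values shown sits.

The compounds shown leave open at what concentration any of them becomes cytotoxic.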